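Swapping a Carbamoylmethyl Arm for a Direct Aryl Group

The source may report more compounds than this note shows. Statements on the series, on what has been measured and on what is new or still open speak of the compounds shown alone.

Of the compounds shown here, three sharing one core have been tested in a functional assay on HeLa cells (Homo sapiens) for inhibition, read by MTT assay, with a stated time of 24 h; a higher number here means a weaker inhibitor, a lower number a stronger inhibitor. Compound 1 `CCOC(=O)C1=Cc2ccccc2OC1(OCc1cn(-c2ccc(F)c(Cl)c2)nn1)C(F)(F)F` gives 22700 nM. Compound 2 `CCOC(=O)C1=Cc2ccccc2OC1(OCc1cn(CC(=O)Nc2ccc(I)cc2Cl)nn1)C(F)(F)F` gives 26100 nM; the step of a 1.1-fold higher number from compound 1 to compound 2 (0.06 log units; within the scatter) is within the scatter. Compound 3 `CCOC(=O)C1=Cc2ccccc2OC1(OCc1cn(CC(=O)Nc2cccc(F)c2)nn1)C(F)(F)F` reaches only the limit of this assay, > 150000 nM, so no number is known for it, and it stands at the limit of > 150000 nM in this assay, at which 1 of the 3 values shown sits, while the other two give measured numbers.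

Compound 4 `CCOC(=O)C1=Cc2ccccc2OC1(OCc1cn(-c2ccc(C)cc2)nn1)C(F)(F)F` has not yet been measured. It differs from compound 3 by 4-methylphenyl in place of ((3-fluorophenyl)carbamoyl)methyl on an aromatic nitrogen, returning to an aryl group set directly on an aromatic nitrogen, as in compound 1. Within the data shown here, two measured steps bear on this: an at least 6.6-fold higher number from compound 1 to compound 3 (0.82 log units; beyond the scatter) and an at least 5.7-fold higher number from compound 2 to compound 3 (0.75 log units; beyond the scatter), both at least modest and both pointing to a weaker inhibitor when the carbamoylmethyl arm is present. Reversing that arm is therefore expected to give a step down in this assay, toward the range of compound 1, as an at least 4.2-fold lower number from compound 3 to compound 4 (0.63 log units; beyond the scatter). Compound 4 is accordingly expected to fall near 35000 nM, within 12000 nM to 120000 nM.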

Compound 4, half-maximal inhibitory concentration: 25100 nM
Compound 4: middle estimate off by 1.4-fold (0.14 log units), on the high side, and the stated range covers the measured number.
By their numbers in this assay, from the lowest: compounds 1, 4 and 2 (each within the scatter of the next). At a limit, above all of these: compound 3.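

At this position, 4-methylphenyl in place of the ((3-fluorophenyl)carbamoyl)methyl arm gives an at least 5.9-fold lower number from compound 3 to compound 4 (0.77 log units; beyond the scatter). The arm alone does not explain the gap, however, since exchanging the arm that carries 2-chloro-4-iodophenyl gives a 1.0-fold lower number from compound 2 to compound 4 (0.02 log units; within the scatter), so compound 2 goes against any rule that the arm always weakens inhibition. Among aryl groups set directly on the aromatic nitrogen, a 1.1-fold higher number from compound 1 to compound 4 (0.04 log units; within the scatter) shows that 4-methylphenyl and 3-chloro-4-fluorophenyl cannot be told apart in this assay, so halogens on this aryl group are not required to reach this level.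

On these data alone, it remains open whether an amine or a carboxylic acid in place of the methyl of 4-methylphenyl would move the number beyond the scatter. How far compound 3 truly lies from the others also stays unknown, as its value is a limit and not a number: the limit of > 150000 nM in this assay, at which 1 of the 4 values shown sits.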